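The source may report more compounds than this note shows. Statements on the series, on what has been measured and on what is new or still open speak of the compounds shown alone.

Measured in a functional assay on MDA-MB-231 cells (Homo sapiens) for cytotoxicity, read by MTT assay, with a stated time of 38 h; a lower number here means a stronger inhibitor, a higher number a weaker inhibitor:
- compound 1 `COc1cc(OC)c2c(=O)c(OCC(=O)N/N=C/c3ccccc3F)c(-c3cc(OC)c(OC)c(OC)c3)oc2c1`: 3400 nM
- compound 2 `COc1cc(OC)c2c(=O)c(OCCCN3CCN(C)CC3)c(-c3cc(OC)c(OC)c(OC)c3)oc2c1`: 30100 nM

Compound 2 has the higher of the two numbers, so it is the weaker inhibitor in this assay. Among the compounds with values here, the only measured step is an 8.9-fold higher number from compound 1 to compound 2 (0.95 log units; beyond the scatter).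

Compound 3 `COc1cc(OC)c2c(=O)c(OCC(=O)N/N=C/c3ccccn3)c(-c3cc(OC)c(OC)c(OC)c3)oc2c1` is not yet measured. The change from compound 2 is a group of 11 heavy atoms (7 carbon, 3 nitrogen, 1 oxygen; one six-membered aromatic ring with 1 hetero atom) in place of a group of 9 heavy atoms (7 carbon, 2 nitrogen; one six-membered non-aromatic ring with 2 hetero atoms), on a saturated chain carbon bound to an oxygen on an aromatic ring. The entering group has a six-membered aromatic ring with 1 hetero atom, whereas the matching group of compound 1 has a six-membered aromatic ring of carbon only. Structurally, compound 3 therefore stands closer to compound 1 than to compound 2.

Within the data shown here, only the step of an 8.9-fold higher number from compound 1 to compound 2 (0.95 log units; beyond the scatter) bears on this change, and it is expected to be largely reversed, giving a lower number in this assay. That expectation rests on compound 1 at 3400 nM, a single reference point, so the range stays wide. The expected step is a 10-fold lower number from compound 2 to compound 3 (1.00 log units; beyond the scatter). For compound 3 the estimated value is 3000 nM, with an expected range of 900 nM to 10000 nM.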

Compound 3, half-maximal inhibitory concentration: 9890 nM
Estimate against measurement, compound 3: 3.3-fold (0.52 log units) below; low and high end bracket the measured number.
By their numbers in this assay, from the lowest: compound 1; then compound 3; then compound 2.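

In this assay, within the data shown here, putting the group that ends in pyridin-2-yl in place of 2-(4-methylpiperazin-1-yl)ethyl, on a saturated chain carbon bound to an oxygen on an aromatic ring, gives a 3.0-fold lower number from compound 2 to compound 3 (0.48 log units; beyond the scatter), so compound 1 is no longer the only compound with a lower number than the piperazine compound. The far end of the entering group also counts: pyridin-2-yl in place of 2-fluorophenyl on a carbon with a double bond to nitrogen gives a 2.9-fold higher number from compound 1 to compound 3 (0.46 log units; beyond the scatter), so the number depends on that ring as well as on the rest of the group. Nothing available on these compounds gives a reason for either difference.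

The step between the two ring ends exchanges the fluorine and the ring nitrogen together, so an unsubstituted phenyl or a pyridin-4-yl on the same carbon would be needed to separate their contributions. On the piperazine side, the compounds shown leave open how a morpholine or a longer chain in place of 2-(4-methylpiperazin-1-yl)ethyl would read in this assay.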